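The compounds below may be only part of what the source reports. "The series", "measured", "known", "first", "only" and "open" are said of these compounds alone.

Compound 1 `O=C1OC2(c3ccccc3)CCCCCN1C2=O` gives 66 mg/kg in a functional assay on the whole organism with Mus musculus as the target, in the maximal electroshock model, with a stated time of 0.5 h; a higher number here means that more compound is needed for the effect, a lower number that less compound is needed. Compound 2 `CCC1(c2ccccc2)OC(=O)NC1=O` gives 86 mg/kg in this assay; the gap between compound 1 and compound 2 lies within the scatter, so the two are not separated. For the measured compounds named here, compound 3 `O=C1O[C@]2(c3ccccc3)CCCCCN1C2=O` is still to be measured. the two compounds have the same atoms and bonds; at least one stereo element is drawn with a configuration in one of them and without one in the other: 1 of 1 stereo elements differ; a stereocentre at a saturated ring carbon is drawn without a configuration in compound 1 and S in compound 3 No step between measured compounds that differ in one place is known, so the size of this change has no precedent here; a single configuration may sit anywhere near the undrawn form, and no step beyond the scatter is expected. Compound 3 is expected to give 60 mg/kg (range 30 mg/kg to 120 mg/kg), an expected step of a 1.1-fold lower number from compound 1 to compound 3 (0.04 log units; within the scatter).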

Compound 3, dose for half-maximal effect: 82 mg/kg
Beside the measured number, compound 3's estimate is 1.4-fold (0.14 log units) below it; measured number inside the range.
By their numbers in this assay, from the lowest: compounds 1, 3 and 2 (each within the scatter of the next).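

In this assay, for the compounds shown here, the step of a 1.2-fold higher number from compound 1 to compound 3 (0.09 log units; within the scatter) is the first one known at this stereocentre, and it leaves the two compounds unseparated. Drawing the S configuration at the saturated ring carbon therefore gives no measurable change here. The comparison is of a defined form with an undrawn one, not of two defined forms: the fact that one of compounds 1 and 3 is drawn with a defined configuration and the other without, at the place where they differ.

Going by these compounds, the number for the R configuration at this carbon stays open. So does the reading in this assay of an amine or a hydroxyl group on the core of compound 3.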